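The source may report more compounds than this note shows. Statements on the series, on what has been measured and on what is new or still open speak of the compounds shown alone.

Measured compounds:
compound 1, `C/C(=N\OC(=O)Nc1ccccc1)c1cccc(-c2ccccc2)c1`, 69 nM
compound 2, `CCCCCCCCCCCCNC(=O)O/N=C(\C)c1cccc(-c2cccs2)c1`, 116 nM
compound 3, `C/C(=N\OC(=O)Nc1ccccc1)c1cccc(-c2cccc(C(N)=O)c2)c1`, 84 nM

In an assay for inhibition of Fatty-acid amide hydrolase 1 (Mus musculus), read by scintillation counting (a higher number here means a weaker inhibitor, a lower number a stronger inhibitor), compound 3 gives 84 nM, a number that lies within the scatter of both compound 1 and compound 2, so the three measured compounds cannot be told apart on this assay. Going by the values given here, the one step that can be read within this set is the change from compound 1 to compound 3, carbamoyl in place of hydrogen on an aromatic carbon, and it gives a 1.2-fold higher number from compound 1 to compound 3 (0.09 log units; within the scatter).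

Compound 4 is `C/C(=N\OC(=O)Nc1ccccc1)c1cccc(-c2cccc(C(=O)NC(=O)Nc3ccccc3)c2)c1`. It grows out of compound 3 by phenylcarbamoyl in place of hydrogen on an amide-type nitrogen. This is a further extension of the very group whose introduction from compound 1 to compound 3 left the number within the scatter. Among the compounds with values here, no measured pair shows what adding phenylcarbamoyl to this amide nitrogen does, so the expectation can only lean on that one neighbouring step and on the observation that all three measured compounds sit close together.

On that basis compound 4 is expected to change little against compound 3, a step of about a 1.2-fold higher number from compound 3 to compound 4 (0.08 log units; within the scatter), with a widened range to allow for the size of the added group. The estimate for compound 4 in this assay is therefore 100 nM, with a range from 35 nM to 300 nM.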

Compound 4, half-maximal inhibitory concentration: > 25000 nM
Compound 4: a limit, no number; the forecaster's own chance of this, stated with the estimate: 5%; middle value at least 250-fold (2.39 log units) away from the limit.
By their numbers in this assay, from the lowest: compounds 1, 3 and 2 (each within the scatter of the next). At a limit, above all of these: compound 4.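

Compound 3 had suggested that this part of the molecule accepts change easily, since carbamoyl in place of hydrogen on an aromatic carbon stayed within the scatter. The amide-type nitrogen of that carbamoyl group behaves very differently: in this assay, phenylcarbamoyl in place of the hydrogen on this nitrogen gives an at least 290-fold higher number from compound 3 to compound 4 (2.47 log units; beyond the scatter), and the whole (phenylcarbamoyl)carbamoyl group in place of hydrogen on the aromatic carbon gives an at least 360-fold higher number from compound 1 to compound 4 (2.55 log units; beyond the scatter), so what holds for the small carbamoyl group does not carry over to this larger one. The value of compound 4, > 25000 nM, is a limit of the assay and not a number: the limit of > 25000 nM in this assay, at which 1 of the 4 values shown sits.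

The compounds shown leave open whether the loss comes with the phenyl ring of the added group or with the carbonyl that joins it to the nitrogen, and a methyl or an acetyl on this same nitrogen would help separate the two. From the compounds shown here alone, it also remains open whether any group larger than hydrogen can sit on this nitrogen without such a loss.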